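The compounds below may be only part of what the source reports. "The series", "measured", "known", "first", "only" and "open" are said of these compounds alone.

Compound 1 `CCO[C@@H]1O[C@H](CNC(=O)c2ccc(S(N)(=O)=O)cc2)[C@@H](O)[C@H](O)[C@H]1O`: 1.54 mL/min/kg
Compound 2 `CCCO[C@@H]1O[C@H](CNC(=O)c2ccc(S(N)(=O)=O)cc2)[C@H](O)[C@H](O)[C@H]1O`: 1.38 mL/min/kg
Compound 3 `CCCO[C@@H]1O[C@H](CNC(=O)c2ccc(S(N)(=O)=O)cc2)[C@@H](O)[C@H](O)[C@H]1N`: 1.42 mL/min/kg

All three compounds were tested in an ADME assay on microsomes from liver (Mus musculus) for metabolic stability; on this read-out lower numbers stand for slow clearance and higher numbers for fast clearance. Compound 3, at 1.42 mL/min/kg, lies within the usual scatter of both other compounds, so these three numbers cannot be told apart.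

Compound 4 `CCCO[C@@H]1O[C@H](CNC(=O)c2ccc(S(N)(=O)=O)cc2)[C@@H](O)[C@H](O)[C@H]1O` has not yet been measured. It arises from compound 3 through a single change, hydroxy in place of amino on a saturated ring carbon.

Going by the values given here, no two measured compounds differ in only one place, so the swap has no direct precedent here. The best guide is that compound 1 at 1.54 mL/min/kg and compound 2 at 1.38 mL/min/kg each differ from compound 3 in their structures, yet neither falls outside the scatter around it. No step beyond the scatter is expected in this assay, in either direction. The estimated change, a 1.0-fold higher number from compound 3 to compound 4 (0.01 log units; within the scatter), is expected to be negligible. For compound 4 the expected value is 1.45 mL/min/kg, with an estimated range of 1 mL/min/kg to 2.2 mL/min/kg.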

Compound 4, clearance: 1.53 mL/min/kg
Compound 4: middle estimate off by 1.1-fold (0.02 log units), on the low side; the measured number falls inside the stated range.
By their numbers in this assay, from the lowest: compounds 2, 3, 4 and 1 (each within the scatter of the next).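

In this assay, the swap of hydroxy in place of amino on this saturated ring carbon now has a direct reading, a 1.1-fold higher number from compound 3 to compound 4 (0.03 log units; within the scatter), and it stays within the scatter. Methyl in place of hydrogen on a saturated chain carbon gives a 1.0-fold lower number from compound 1 to compound 4 (0.00 log units; within the scatter), so lengthening the chain in this way also produces no step beyond the scatter. Reversing a single drawn stereocentre at a saturated ring carbon gives a 1.1-fold higher number from compound 2 to compound 4 (0.04 log units; within the scatter), also within the scatter, and this step can be read as one of configuration alone: the fact that compounds 2 and 4 differ only in the configuration as drawn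

As far as these compounds go, whether a larger group at the same ring carbon, such as methoxy or a carboxylic acid, would move the clearance beyond the scatter remains open. So does the effect of a chain longer than propoxy, such as butoxy or hexyloxy.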